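Aryl variation on the piperazine nitrogen, all at limit

The source may hold more compounds than are shown below. What is called first, only, known or untested is meant among the compounds shown, and "the series" means these compounds.

Compound 1 `CCCn1c(=O)[nH]c2nc(-c3ccc(S(=O)(=O)N4CCN(c5ccc(F)cc5)CC4)cc3)[nH]c2c1=O`: in an assay on CHO cells for displacement of a labelled ligand from adenosine receptor A3 (Homo sapiens), read by scintillation counting, with a stated time of 45 min, in the presence of a further agent that is not named here (a higher number here means a weaker inhibitor, a lower number a stronger inhibitor), compound 1 gives > 1000 nM, a limit of the assay.
Compound 2 `CCCn1c(=O)[nH]c2nc(-c3ccc(S(=O)(=O)N4CCN(c5ccc(Cl)cc5F)CC4)cc3)[nH]c2c1=O`: in this assay compound 2 gives > 1000 nM, also a limit.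
Compound 3 `CCCn1c(=O)[nH]c2nc(-c3ccc(S(=O)(=O)N4CCN(C(C)c5ccccc5)CC4)cc3)[nH]c2c1=O`: in this assay compound 3 gives > 1000 nM, again a limit.

Compound 3 therefore stands only at a limit, as do both other values shown; the limit of > 1000 nM in this assay, at which 3 of the 3 values shown sit, records that every value in this set sits there. The three steps among the measured compounds, a step that the two limits leave unreadable from compound 1 to compound 2, a step that the two limits leave unreadable from compound 1 to compound 3 and a step that the two limits leave unreadable from compound 2 to compound 3, cannot be read in size or direction, since each joins two limits.

Compound 4 `CCCn1c(=O)[nH]c2nc(-c3ccc(S(=O)(=O)N4CCN(c5ccccc5Cl)CC4)cc3)[nH]c2c1=O` differs from compound 3 by 2-chlorophenyl in place of 1-phenylethyl on an amine nitrogen in a ring. The measured steps bear on it only by showing that three different groups on this ring nitrogen all leave the series at the limit, so no readable step is expected in this assay. The expected step is estimated as a step that the limit leaves unreadable from compound 3 to compound 4, most probably again returned as a limit. Compound 4 is expected at 3000 nM, with a range from 1000 nM to 10000 nM.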

Compound 4, inhibition constant: > 1000 nM
Compound 4: no number, only a limit; the forecaster's own chance of this, stated with the estimate: 85%; the middle value does not contradict the limit.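

Compound 4 gives no readable step to compound 1, compound 2 or compound 3, since all four sit at a limit in this assay: the limit of > 1000 nM in this assay, at which 4 of the 4 values shown sit.

The compounds shown leave open whether any group on this ring nitrogen gives a numerical inhibition constant in this assay, and how these four compounds rank.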